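A few compounds are considered here, and "the series" means these few. Any claim that something is new, unique, unknown or untested is made for them only; others in the source may bear on it.

Working notes on a small series tested in a functional assay on the whole organism with Rattus norvegicus as the target, at a dose of 40 mg/kg by the intraperitoneal route; a higher number here means more inhibition at the dose given (going by the name of the read-out), a lower number less inhibition. Of the compounds shown here, two have numbers so far. Compound 1 `Cc1nc2c(OCc3cccs3)cccn2c1N` gives 70% in this assay. Compound 2 `Cc1nc2c(OCc3ccccc3)cccn2c1CN` gives 46% in this assay, which places compound 2 lowest of the two, with compound 1 standing higher by a gap beyond the usual scatter of repeated runs. Among the compounds with values here, no step between compounds that differ in a single place is available, so the weight of any one structural change on the inhibition remains unknown.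

The next compound, compound 3 `Cc1nc2c(OCc3ccccc3)cccn2c1N(C)C`, has not been measured. It departs from compound 2 in one place: dimethylamino in place of aminomethyl on an aromatic carbon. The aminomethyl group is thus replaced by a dimethylamino group on the same aromatic carbon of the five-membered ring.

Within the data shown here, with no comparable step in hand, the expected step from compound 2 to compound 3 is modest, estimated as a number 6 percentage points higher from compound 2 to compound 3 (within the scatter), leaning upward only because compound 2 gives 46% and sits at the low end of the two numbers. Compound 3 is therefore estimated at 52% in this assay, within a range from 28% to 76%.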

Compound 3, a percentage reported as inhibition, in the whole organism at one dose (the size of the read-out at that dose, not a potency): 76%
The estimate for compound 3 lay 24 percentage points below the measured number, within the range that was stated.
By their numbers in this assay, from the lowest: compound 2; then compounds 1 and 3 (each within the scatter of the next).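

In this assay, within the data shown here, dimethylamino in place of aminomethyl on the aromatic carbon of the five-membered ring gives a number 30 percentage points higher from compound 2 to compound 3 (beyond the scatter), the first step between compounds that differ in one place, and it shows that the group at this carbon bears on the inhibition at the dose given. The change alters several things at once: the nitrogen now sits directly on the ring carbon, the hydrogen-bond donors go from 1 to 0, and the heavy atoms go from 2 to 3, so this single step cannot assign the gain to any one of them. Among these compounds, nothing measured so far speaks to the reason for the step.

The compounds shown leave open whether a methylamino group, with one methyl on the nitrogen, or a diethylamino group or a morpholine ring at the same carbon would give a similar read-out, and whether a longer chain such as aminoethyl would follow aminomethyl. They also leave open whether the step carries over to the core of compound 1, and, with a single dose, how the compounds rank in potency.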